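Ester variation on a hydroxypropyl adenine series: cytotoxicity notes

The source may report more compounds than this note shows. Statements on the series, on what has been measured and on what is new or still open speak of the compounds shown alone.

Measured so far:
compound 1 `CC(C)OC(=O)C(O)Cn1cnc2c(N)ncnc21` gives > 400 ug/mL in a functional assay on HeLa cells (Homo sapiens) for cytotoxicity; a higher number here means that more compound is tolerated, a lower number that less compound is tolerated; this value is a limit of the assay, not a number.
compound 2 `CC(C)CCOC(=O)C(O)Cn1cnc2c(N)ncnc21` gives 400 ug/mL in this assay.

Among the compounds with values here, compound 2 is the only member with a number in this assay; the one further value is a limit. The step of a number no higher from compound 1 to compound 2 (the limit leaves the size open) cannot be sized, because the limit of > 400 ug/mL in this assay, at which 1 of the 2 values shown sits, leaves open how far compound 1 actually lies from compound 2. Compound 2 therefore stands at a number that may sit at, or somewhat under, where compound 1 sits.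

Compound 3 `CCC(C)OC(=O)C(O)Cn1cnc2c(N)ncnc21` is not yet measured. It differs from compound 2 as follows: sec-butyl in place of isopentyl on an oxygen next to a carbonyl group. This is the same kind of change as the measured step, namely a swap of the alkyl group on an oxygen next to a carbonyl group, and that step gave no readable size. The sec-butyl group is smaller than isopentyl and larger than isopropyl, so no shift beyond the scatter is expected in this assay, and no change at the digits printed from compound 2 to compound 3 (within the scatter) is the expected step. Compound 3 is estimated at 400 ug/mL, within 200 ug/mL to 800 ug/mL, with a fair chance that only the same limit is reported.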

Compound 3, minimum cytotoxic concentration: > 400 ug/mL
Compound 3 was reported as a limit (the forecaster's own chance of this, stated with the estimate: 50%); the middle value lies on the limit itself.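

Compound 3 gives > 400 ug/mL in this assay, which is a limit of the assay and not a number. Within the data shown here, the swap to sec-butyl reads as a number no lower from compound 2 to compound 3 (the limit leaves the size open), and compound 2, at 400 ug/mL, remains the only member of the series with a number, so isopentyl is so far the only one of the three alkyl groups on this oxygen to give one. Neither this step nor the one between compound 1 and compound 3 can be sized, because the values sit at the limit of the assay: the limit of > 400 ug/mL in this assay, at which 2 of the 3 values shown sit.

The compounds shown leave open whether a longer chain such as octyl, or a benzyl group, on this oxygen would give a number clearly apart from that of compound 2 in this assay. Also open, going by these compounds, is how the free carboxylic acid, with no alkyl group on this oxygen, would read in this assay.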